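Compound 4: trifluoromethyl in place of chloro

A few compounds are considered here, and "the series" means these few. Any claim that something is new, unique, unknown or untested is made for them only; others in the source may bear on it.

Going by the values given here, compound 3 `C#CCNC1CCc2c(SCc3cccc(Cl)c3)cccc21` gives 1090 nM in an ADME assay on isolated protein for inhibition of Amine oxidase [flavin-containing] B (Homo sapiens) (a lower number here means a stronger inhibitor, a higher number a weaker inhibitor), the lowest of the two numbers so far. Compound 1 `C#CCNC1CCc2c(SCc3cccc(F)c3)cccc21` gives 11600 nM in this assay, and compound 2 `C#CCNC1CCc2c(SCc3ccccc3)cccc21` is reported in this assay as "not active" (no number reported), without a number. The step of an 11-fold lower number from compound 1 to compound 3 (1.03 log units; beyond the scatter) shows that the group on this aromatic carbon moves the number well beyond the scatter.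

Compound 4 `C#CCNC1CCc2c(SCc3cccc(C(F)(F)F)c3)cccc21` carries the change (trifluoromethyl in place of chloro on an aromatic carbon). Among the compounds with values here, no measured step exchanges chloro for trifluoromethyl, so an 11-fold lower number from compound 1 to compound 3 (1.03 log units; beyond the scatter) is the only guide; it says the position matters, not which way the new group acts. With compound 2 inactive and compound 1 weak, compound 3 stands apart, and a drift back toward higher numbers is the likelier outcome, though a number within the scatter of compound 3 cannot be excluded. Compound 4 is expected to give 1800 nM in this assay, within 450 nM to 7000 nM. The estimated step of a 1.7-fold higher number from compound 3 to compound 4 (0.22 log units; within the scatter) is expected to stay modest.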

Compound 4, half-maximal inhibitory concentration: 7710 nM
Compound 4: the middle estimate sits 4.3-fold (0.63 log units) below what was measured, outside the stated range (above it).
By their numbers in this assay, from the lowest: compound 3; then compounds 4 and 1 (each within the scatter of the next).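

In this assay, the change from chloro to trifluoromethyl is not neutral at this aromatic carbon: the series shows a 7.1-fold higher number from compound 3 to compound 4 (0.85 log units; beyond the scatter), so the low number of compound 3 does not carry over to this larger replacement. The comparison with fluoro gives a 1.5-fold lower number from compound 1 to compound 4 (0.18 log units; within the scatter), which places the fluoro and trifluoromethyl compounds level and leaves chloro alone among the three groups with a number in giving a clearly lower one. No measurement here explains the preference for chloro.

The compounds shown leave open whether bromo, methyl or a nitrile on this aromatic carbon would hold the number of compound 3. They also leave open whether an amine or a carboxylic acid there would retain any measurable inhibition.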